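The compounds below may be only part of what the source reports. "The series", "measured", "known", "first", "only" and "open" are said of these compounds alone.

Compound 1 `O=C(Nc1ncc(C(Oc2ccc3cc(Br)ccc3c2)c2ccc(Cl)cc2)s1)C1CCCO1` — "not toxic" (no number reported)
Compound 2 `COc1ccc(C(=O)Nc2ncc(C(Oc3ccc4cc(Br)ccc4c3)c3ccc(Cl)cc3)s2)cc1` — > 50000 nM
Compound 3 `COc1ccc(C(=O)Nc2ncc(C(Sc3ccc4ccccc4c3)c3ccc(Cl)cc3)s2)cc1` — "not toxic" (no number reported)

In an ADME assay on HepG2 2.2.15 cells (Homo sapiens) for cytotoxicity (on this read-out lower numbers stand for higher toxicity in this test and higher numbers for lower toxicity in this test), compound 2 gives > 50000 nM, which is a limit of the assay and not a number. Compound 1 is recorded in this assay as "not toxic" (no number reported), and compound 3 as "not toxic" (no number reported). Compound 2 thus stands at the limit of > 50000 nM in this assay, at which 1 of the 3 values shown sits, while the other two entries carry no single number at all.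

Compound 4 `COc1ccc(C(=O)Nc2ncc(C(Oc3ccc4cc(Br)ccc4c3)c3ccc(Br)cc3)s2)cc1` differs from compound 2 by bromo in place of chloro on an aromatic carbon. Among the compounds with values here, no measured step of this kind exists among the three compounds. From compound 2 to compound 4 a step no larger than the scatter is expected in this assay a step that the limit leaves unreadable from compound 2 to compound 4. Compound 4 is therefore estimated at 60000 nM, ranging from 30000 nM to 120000 nM.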

Compound 4, half-maximal cytotoxic concentration: > 50000 nM
Compound 4 ended at the assay's limit (the forecaster's own chance of this, stated with the estimate: 80%); the middle value lies beyond the limit too.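

In this assay, no step can be read between compound 2 and compound 4, since both stand at a limit of the assay and not at a number: the limit of > 50000 nM in this assay, at which 2 of the 4 values shown sit.

The compounds shown leave open whether bromo in place of chloro changes the cytotoxic concentration at all.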